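Acetylating the Amine on a Bicyclic Sulfonamide

This account rests on a few compounds, and the source may have more. Where it says the series, first, only, none or still open, it means among the compounds named here.

Compound 1 `CC1(C)[C@@H]2CC[C@@]1(CS(=O)(=O)N1CCN(c3ccc(C(F)(F)F)cn3)CC1)C(O)C2` and compound 2 `CC1(C)[C@@H]2CC[C@@]1(CS(=O)(=O)N1CCN(c3ccc(C(F)(F)F)cn3)CC1)C(N)C2` share one core and differ only at a saturated ring carbon, where compound 1 carries a hydroxy group and compound 2 an amino group. In a functional assay on CHO-K1 cells for antagonist activity at C-X-C chemokine receptor type 3 (Homo sapiens), read by FLIPR and calcium flux (a lower number here means a stronger inhibitor, a higher number a weaker inhibitor), compound 1 gives 158 nM, and compound 2 gives 794 nM. For the measured compounds named here, of these two numbers, compound 2 has the higher one, meaning the weaker inhibition; its only neighbour is compound 1, and the step of a 5.0-fold higher number from compound 1 to compound 2 (0.70 log units; beyond the scatter) lies beyond the usual scatter.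

Compound 3 `CC(=O)NC1C[C@H]2CC[C@]1(CS(=O)(=O)N1CCN(c3ccc(C(F)(F)F)cn3)CC1)C2(C)C` takes the next step from compound 2: acetyl in place of hydrogen on an amine nitrogen. Going by the values given here, only one measured step touches this position, the change from hydroxy to amino just described, and it weakened inhibition. Among the compounds with values here, no measured step shows what happens when the amino hydrogen is replaced by an acetyl group, so the expectation rests on the two numbers alone.

The estimated change a 1.6-fold lower number from compound 2 to compound 3 (0.20 log units; within the scatter) is expected to be small, with the number for compound 3 somewhat lower than that of compound 2 but within reach of it. Compound 3 is expected to give about 500 nM, between 150 nM and 1600 nM.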

Compound 3, half-maximal inhibitory concentration: 2000 nM
Compound 3: the middle estimate sits 4.0-fold (0.60 log units) below what was measured, and the stated range ends below it.
By their numbers in this assay, from the lowest: compound 1; then compound 2; then compound 3.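

In this assay, acetyl on the amine nitrogen does not win back what the change from hydroxy to amino lost; inhibition weakens further, with a 2.5-fold higher number from compound 2 to compound 3 (0.40 log units; beyond the scatter). Replacing hydroxy directly with acetamido gives a 13-fold higher number from compound 1 to compound 3 (1.10 log units; beyond the scatter), so the group on this saturated ring carbon can strongly change the result, and among these three compounds the hydroxy group of compound 1 gives the strongest inhibition. Nothing available explains why the numbers rise in this order.

The compounds shown leave open whether the weakening depends on the whole acetyl group or would also appear with a simple methyl group on the same nitrogen, and whether a longer acyl chain, such as propanoyl, would weaken inhibition further. They also leave open whether any other group at this ring carbon, such as methoxy or a carboxylic acid, could match or surpass the hydroxy group of compound 1.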